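The source may report more compounds than this note shows. Statements on the series, on what has been measured and on what is new or still open speak of the compounds shown alone.

Compound 1, `CCCS(=O)(=O)Nc1ccc(F)c(C(=O)c2n[nH]c3ncc(-c4ccccc4F)cc23)c1F`: in an assay for binding affinity to dual specificity mitogen-activated protein kinase kinase 4 (Homo sapiens), read by KINOMEscan, tested at 100 nM (a lower number here means a stronger effect, a higher number a weaker effect of the compound at the concentration tested), compound 1 gives 2%.
Compound 2, `CCCS(=O)(=O)Nc1ccc(F)c(C(=O)c2n[nH]c3ncc(-c4ccccc4OC)cc23)c1F`: in this assay compound 2 gives 1.9%.
Compound 3, `CCCS(=O)(=O)Nc1ccc(F)c(C(=O)c2n[nH]c3ncc(-c4ccccc4O)cc23)c1F`: in this assay compound 3 gives 9%.

Compound 3 has nominally the highest of the three numbers, but neither gap to it is beyond the scatter: a number 7 percentage points higher from compound 1 to compound 3 (within the scatter) and a number 7.1 percentage points higher from compound 2 to compound 3 (within the scatter). Compound 4, `CCCS(=O)(=O)Nc1ccc(F)c(C(=O)c2n[nH]c3ncc(-c4ccc(O)cc4)cc23)c1F`, has not yet been measured. It differs from compound 3 by 4-hydroxyphenyl in place of 2-hydroxyphenyl on an aromatic carbon.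

All three measured steps change what sits on the phenyl at one and the same position: a number 0.1 percentage points lower from compound 1 to compound 2 (within the scatter), a number 7 percentage points higher from compound 1 to compound 3 (within the scatter), a number 7.1 percentage points higher from compound 2 to compound 3 (within the scatter). Among the measured compounds shown here, none of them moves the hydroxy from 2-hydroxyphenyl to 4-hydroxyphenyl, so there is no direct precedent; what the steps do show is that varying this phenyl has left the read-out essentially unmoved. The step from compound 3 to compound 4 is therefore expected to be a number 1 percentage points lower from compound 3 to compound 4 (within the scatter), with no change beyond the scatter. Compound 4 is thus estimated at 8%, within a range from 1% to 25%.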

Compound 4, a percentage reported as activity, at one concentration (the size of the read-out at that concentration, not a potency): 0.75%
Compound 4: middle estimate off by 7.3 percentage points, on the high side; the measured number lies below the stated range.
By their numbers in this assay, from the lowest: compounds 4, 2, 1 and 3 (each within the scatter of the next).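

Moving the hydroxy from 2-hydroxyphenyl to 4-hydroxyphenyl is the first change here that alters where the group sits on this phenyl rather than which group it is, and in this assay it gives a number 8.3 percentage points lower from compound 3 to compound 4 (within the scatter), which leaves the two placements indistinguishable. The comparisons with the other two compounds read the same way, a number 1.2 percentage points lower from compound 2 to compound 4 (within the scatter) and a number 1.3 percentage points lower from compound 1 to compound 4 (within the scatter), so all four substituted phenyls remain within the scatter of one another at the concentration tested. Nothing available bears on why the read-out stays unmoved at this position.

On these data alone, whether an amine or a carboxylic acid on this phenyl would also leave the read-out unmoved remains open. As far as these compounds go, it is also open whether the two hydroxyphenyl placements would separate in a measure of potency rather than a read-out at one concentration.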